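A methoxy for a fluoro on a well-tolerated scaffold

A few compounds are considered here, and "the series" means these few. Any claim that something is new, unique, unknown or untested is made for them only; others in the source may bear on it.

Compound 3 `Cn1c(-c2ccc(F)cc2)cnc1NC(=O)c1ccc(F)cc1` in a toxicity assay on THP-1 cells (Homo sapiens) for inhibition (a lower number here means that less compound is tolerated, a higher number that more compound is tolerated), gives > 100000 nM, which is a limit of the assay and not a number. Compound 1 `COc1ccc(-c2cnc(NC(=O)c3ncc[nH]3)n2C)cc1` gives > 100000 nM in this assay, again a limit rather than a measured number. Compound 2 `COc1ccc(-c2cnc(NC(=O)c3ccccc3O)n2C)cc1` gives > 100000 nM in this assay, also a limit. For the measured compounds named here, the one step between measured compounds that differ in a single place, a step that the two limits leave unreadable from compound 1 to compound 2, is thus unreadable, and the limit of > 100000 nM in this assay, at which 3 of the 3 values shown sit, records where all three values sit. Compound 4 `COc1ccc(-c2cnc(NC(=O)c3ccc(F)cc3)n2C)cc1` differs from compound 3 by methoxy in place of fluoro on an aromatic carbon, the group standing on an aromatic carbon of a six-membered aromatic ring of carbon only. Going by the values given here, no measured step bears on this change, and the only measured step cannot be read. In this assay compound 4 is therefore expected to sit at the same limit as its neighbours, with a number no higher from compound 3 to compound 4 (the limit leaves the size open) expected to be no step beyond the scatter. The estimate for compound 4 in this assay is 100000 nM, in the range 50000 nM to 200000 nM, and most likely reported only as a limit.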

Compound 4, half-maximal cytotoxic concentration: >= 50000 nM
Compound 4: only a limit was reported; the forecaster's own chance of this, stated with the estimate: 85%; the middle value is on the limit's open side.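

In this assay compound 4 gives >= 50000 nM which is a limit of the assay and not a number. The steps to compound 4 from compound 1, compound 2 and compound 3 cannot be read, as all four values are limits. The compounds shown leave open what concentration of any of them is cytotoxic in this assay and whether methoxy in place of fluoro alters it.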